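Extending the methoxy group of compound 3 to a carbamoylmethoxy group

A few compounds are considered here, and "the series" means these few. Any claim that something is new, unique, unknown or untested is made for them only; others in the source may bear on it.

Compound 3, with structure `CNC(=O)[C@H]1O[C@@H](n2cnc3c(NCc4cc(Cl)ccc4OC)ncnc32)[C@H](O)[C@@H]1N`, was tested in an assay on isolated protein for binding affinity to adenosine receptor A3 (Homo sapiens) (a higher number here means a weaker inhibitor, a lower number a stronger inhibitor), and gives 15 nM. Among the three numbers in hand this is the second highest: compound 2, `CNC(=O)[C@H]1O[C@@H](n2cnc3c(NCc4cc(Cl)cc(Cl)c4)ncnc32)[C@H](O)[C@@H]1N`, gives 25 nM, and the step of a 1.7-fold lower number from compound 2 to compound 3 (0.22 log units; within the scatter) is within the scatter, so no order between these two can be claimed. Compound 1, `CNC(=O)[C@H]1O[C@@H](n2cnc3c(NCc4cc(OC)ccc4OC)ncnc32)[C@H](O)[C@@H]1O`, gives 3.9 nM, a clearly lower number than compound 3; compound 1 differs from compound 3 in more than one place, so the two values are simply noted side by side.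

Compound 4, `CNC(=O)[C@H]1O[C@@H](n2cnc3c(NCc4cc(Cl)ccc4OCC(N)=O)ncnc32)[C@H](O)[C@@H]1N`, is not yet measured. It differs from compound 3 as follows: carbamoyl in place of hydrogen on a saturated chain carbon bound to an oxygen on an aromatic ring.

Going by the values given here, none of the measured steps touches this position. Among the compounds with values here, the only single-place step available, from compound 2 to compound 3, concerns a swap of the whole aryl group, not the chain on the aromatic oxygen, so it offers no direct guide. In the absence of a bearing step, the expectation for compound 4 in this assay is a small step in either direction, with a wide uncertainty, from compound 3 given as a 2.0-fold higher number from compound 3 to compound 4 (0.30 log units; within the scatter). Compound 4 is therefore estimated at 30 nM, within a range from 8 nM to 120 nM.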

Compound 4, inhibition constant: 6.8 nM
Beside the measured number, compound 4's estimate is 4.4-fold (0.64 log units) above it; measured number below the stated range.
By their numbers in this assay, from the lowest: compounds 1 and 4 (each within the scatter of the next); then compounds 3 and 2 (each within the scatter of the next).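

In this assay, going by these compounds alone, replacing methoxy with carbamoylmethoxy gives a 2.2-fold lower number from compound 3 to compound 4 (0.34 log units; beyond the scatter), the first reading of any change on the chain at the aromatic oxygen. It shows that this place accepts carbamoyl, with its three heavy atoms, one hydrogen-bond donor, one hydrogen-bond acceptor and no net charge, and that the number does not rise but falls by a modest step just beyond the scatter. Nothing at hand explains this fall.

The compounds shown do not separate the contribution of the carbamoyl group from that of the longer chain, so it remains open how a plain ethoxy group, a carboxylic acid in place of the primary amide, or an amine at the end of the chain would read at this place. Going by these compounds, it also remains open whether carbamoylmethoxy would give a similar step on the core of compound 1, which carries a hydroxyl where compound 3 carries an amine, or in place of the other methoxy group of compound 1.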